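Spiro triazolylmethyl amides: antiproliferative limits in a short series

This account rests on a few compounds, and the source may have more. Where it says the series, first, only, none or still open, it means among the compounds named here.

Measured compounds:
compound 1 `Cc1ccccc1-n1nncc1CN1C(=O)C2(C(C#N)=C(N)Oc3c2c2nc4ccccc4nc2c2ccccc32)c2ccccc21`, > 50000 nM
compound 2 `Cc1cccc(-n2nncc2CN2C(=O)C3(C(C#N)=C(N)Oc4c3c3nc5ccccc5nc3c3ccccc43)c3ccccc32)c1`, > 50000 nM
compound 3 `Cc1ccccc1-n1nncc1CN1C(=O)C2(C(C#N)=C(N)Oc3c(N)cc4nc5ccccc5nc4c32)c2ccccc21`, > 50000 nM

In a functional assay on MCF7 cells (Homo sapiens) for antiproliferative activity, read by MTT assay, with a stated time of 48 h (a higher number here means a weaker inhibitor, a lower number a stronger inhibitor), compound 1 gives > 50000 nM, which is a limit of the assay and not a number. In this assay compound 2 likewise gives > 50000 nM, again a limit. Compound 3 gives > 50000 nM in this assay, also a limit. All three measured values therefore sit at the limit of > 50000 nM in this assay, at which 3 of the 3 values shown sit.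

The change from compound 1 to compound 2 is 3-methylphenyl in place of 2-methylphenyl on an aromatic nitrogen. Its step, a step that the two limits leave unreadable from compound 1 to compound 2, cannot be sized, since both ends are limits. The difference between the core of compound 1 and the core of compound 3 is not broken down here.

Compound 4 `Cc1cccc(-n2nncc2CN2C(=O)C3(C(C#N)=C(N)Oc4c(N)cc5nc6ccccc6nc5c43)c3ccccc32)c1` is not yet measured. It differs from compound 3 by 3-methylphenyl in place of 2-methylphenyl on an aromatic nitrogen, the same change as that from compound 1 to compound 2; the two place descriptions agree word for word.

For compound 4 the expectation rests on compound 1 and compound 2 both standing at the limit of > 50000 nM in this assay, at which 3 of the 3 values shown sit, with the step that the two limits leave unreadable from compound 1 to compound 2 unreadable, and on compound 3 giving > 50000 nM in this assay. The step from compound 3 to compound 4 is expected to be about a step that the limit leaves unreadable from compound 3 to compound 4, which is to say no readable movement. Compound 4 is therefore estimated at 60000 nM in this assay, with a range of 20000 nM to 200000 nM, and most likely only a limit will be reported.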

Compound 4, half-maximal inhibitory concentration: > 50000 nM
Compound 4 gave a limit, no number; the forecaster's own chance of this, stated with the estimate: 85%; the middle value is on the limit's open side.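

In this assay compound 4 gives > 50000 nM as a limit of the assay and not a number. Compound 3 also stands at a limit, so no step can be read between compound 3 and compound 4: the limit of > 50000 nM in this assay, at which 4 of the 4 values shown sit. The compounds shown leave open whether 3-methylphenyl in place of 2-methylphenyl, or the difference between the two cores, changes the read-out in this assay at all.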